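Varying the aryl group on the carbonyl carbon

This account rests on a few compounds, and the source may have more. Where it says the series, first, only, none or still open, it means among the compounds named here.

Going by the values given here, compound 2 `O=C(/C=C/c1ccc2c(c1)B(O)OC2)c1ccccc1F` gives 2200 nM in a functional assay on MDA-MB-231 cells (Homo sapiens) for cytotoxicity, read by MTT assay, with a stated time of 48 h (a higher number here means a weaker inhibitor, a lower number a stronger inhibitor), the lowest of the two numbers so far; compound 1 `O=C(/C=C/c1ccc2c(c1)B(O)OC2)c1cccs1` gives 4600 nM in this assay. Among the compounds with values here, the single measured step at this place, a 2.1-fold lower number from compound 1 to compound 2 (0.32 log units; beyond the scatter), is modest. Compound 3 `Cc1cccc(C(=O)/C=C/c2ccc3c(c2)B(O)OC3)c1` differs from compound 2 by 3-methylphenyl in place of 2-fluorophenyl on a carbonyl carbon. Within the data shown here, only that one step bears on the change, and it concerns a different pair of groups, so no step beyond the scatter is expected in this assay. Compound 3 is expected to give about 2500 nM in this assay, within 1200 nM to 5500 nM, which would mean a 1.1-fold higher number from compound 2 to compound 3 (0.06 log units; within the scatter).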

Compound 3, half-maximal inhibitory concentration: 4500 nM
For compound 3 the middle estimate is 1.8-fold (0.26 log units) below the measured one; the range from low to high includes it.
By their numbers in this assay, from the lowest: compound 2; then compounds 3 and 1 (each within the scatter of the next).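

In this assay, 3-methylphenyl in place of 2-fluorophenyl on a carbonyl carbon gives a 2.0-fold higher number from compound 2 to compound 3 (0.31 log units; beyond the scatter) and so a second step beyond the scatter at this position, here between two six-membered aromatic rings of carbon only with equal heavy-atom counts. Set against thiophen-2-yl, 3-methylphenyl gives a 1.0-fold lower number from compound 1 to compound 3 (0.01 log units; within the scatter) as the reading, which leaves 2-fluorophenyl as the only one of the three groups apart from the others. No measurement at hand bears on the reason for this difference.

Going by these compounds, whether 3-fluorophenyl would read like 2-fluorophenyl or like 3-methylphenyl stays open. So does the reading for a phenyl ring carrying an amine or a carboxylic acid.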